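Flipping One Stereocentre of Compound 3

The source may report more compounds than this note shows. Statements on the series, on what has been measured and on what is new or still open speak of the compounds shown alone.

Measured so far in a functional assay on HL-60 cells (Homo sapiens) for antiproliferative activity, read by MTT assay; a higher number here means a weaker inhibitor, a lower number a stronger inhibitor:
- compound 1 `O[C@@H]1[C@@H](OCc2ccccc2)[C@H](OCc2ccccc2)[C@@H](COCc2ccccc2)O[C@@H]1CC1CCCCC1`: 17200 nM
- compound 2 `C=C[C@H]1O[C@H](COCc2ccccc2)[C@@H](OCc2ccccc2)[C@H](OCc2ccccc2)[C@H]1O`: "not active" (no number reported)
- compound 3 `CCC[C@@H]1O[C@H](COCc2ccccc2)[C@@H](OCc2ccccc2)[C@H](OCc2ccccc2)[C@H]1O`: 11700 nM

Compound 3 gives 11700 nM and compound 1 gives 17200 nM. These two numbers lie within the usual scatter of repeated measurements, so they cannot be ranked. Compound 2 was reported as "not active" (no number reported), without a number, so this family does not always give a measurable value.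

The next compound is compound 4 `CCC[C@H]1O[C@H](COCc2ccccc2)[C@@H](OCc2ccccc2)[C@H](OCc2ccccc2)[C@H]1O`, which has the same atoms and bonds as compound 3. The two differ only in configuration as drawn: the two compounds have the same atoms and bonds and differ only in configuration as drawn: 1 of 5 stereo elements differ; a stereocentre at a saturated ring carbon is drawn S in compound 3 and R in compound 4. A stereocentre at a saturated ring carbon is drawn S in compound 3 and R in compound 4.

Among the compounds with values here, no pair of measured compounds shows what a change of this kind does, so the expectation rests mainly on compound 3 at 11700 nM. The direction is uncertain, with a slight lean toward a weaker inhibitor and nothing expected beyond the scatter. The expected change is a 1.2-fold higher number from compound 3 to compound 4 (0.08 log units; within the scatter). In this assay, the estimated value for compound 4 is 14000 nM, with an expected range from 6000 nM to 35000 nM.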

Compound 4, half-maximal inhibitory concentration: 28200 nM
Beside the measured number, compound 4's estimate is 2.0-fold (0.30 log units) below it, and the stated range covers the measured number.
By their numbers in this assay, from the lowest: compounds 3, 1 and 4 (each within the scatter of the next, the first and the last beyond it).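

In this assay, within the data shown here, this is the first direct test of the stereocentre at the saturated ring carbon, and it gives a 2.4-fold higher number from compound 3 to compound 4 (0.38 log units; beyond the scatter). This modest step lies beyond the scatter, so within this pair the S drawing goes with the stronger inhibitor, and the step can be tied to that single centre: the fact that compounds 3 and 4 differ only in the configuration as drawn

The other step, with ethyl in place of cyclohexyl on a saturated chain carbon bound to a saturated ring carbon, is a 1.6-fold higher number from compound 1 to compound 4 (0.21 log units; within the scatter); it lies within the scatter, so that swap cannot be ranked with the R drawing in place.

On these data alone, it remains open whether the same flip would matter with a different group on that ring carbon, such as a longer chain or an amine. The compounds shown also cannot tell why the S drawing goes with the lower number, or whether the gap would hold on cells other than those of this assay.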